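The source may report more compounds than this note shows. Statements on the series, on what has been measured and on what is new or still open speak of the compounds shown alone.

Compounds measured in a functional assay on MCF7 cells (Homo sapiens) for inhibition, read by MTT assay, with a stated time of 72 h; a higher number here means a weaker inhibitor, a lower number a stronger inhibitor:

Compound 1 `Cc1ccc(-n2cc(CNC(=O)c3cccc4c3cnn4C(C)C)nn2)cc1C` gives > 40000 nM, a limit of the assay and not a number.

Compound 2 `Cc1ccc(-n2cc(CNC(=O)c3cccc4c3cnn4C(C)C)nn2)c(C)c1` gives > 40000 nM, likewise a limit and not a number.

For the measured compounds named here, compound 1 thus stands at the edge of what this assay can report, and the one other value shown is also a limit. Going by the values given here, the only step between measured compounds, a step that the two limits leave unreadable from compound 1 to compound 2, cannot be read, since the limit of > 40000 nM in this assay, at which 2 of the 2 values shown sit, shows both ends sitting at the same limit. Compound 3 `Cc1cccc(-n2cc(CNC(=O)c3cccc4c3cnn4C(C)C)nn2)c1` differs from compound 1 by hydrogen in place of methyl on an aromatic carbon. Among the compounds with values here, no readable measured step bears on this change; the unreadable one from compound 1 to compound 2 is the only comparison available, and it gives no size or direction. Compound 3 is therefore expected to remain at or beyond the same limit in this assay, and its estimate is 60000 nM with a range from 20000 nM to 200000 nM. That expectation amounts to a step that the limit leaves unreadable from compound 1 to compound 3, most likely reported again only as a limit.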

Compound 3, half-maximal inhibitory concentration: > 40000 nM
Compound 3 was reported as a limit (the forecaster's own chance of this, stated with the estimate: 85%); the middle value is on the limit's open side.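

Compound 3 sits at the same limit as compound 1 and compound 2, so no step among these three compounds can be read: the limit of > 40000 nM in this assay, at which 3 of the 3 values shown sit.

The compounds shown leave open whether any methyl pattern on this phenyl ring would give a readable value at all.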